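A few compounds are considered here, and "the series" means these few. Any claim that something is new, unique, unknown or untested is made for them only; others in the source may bear on it.

Measured so far:
Compound 1, `Cc1ncc(CO)c2c(Nc3ccccn3)c(N)oc12`, in a functional assay on HEK293 cells for agonist activity at Toll-like receptor 8 (Homo sapiens), read by reporter gene assay (a lower number here means that less compound is needed, a higher number that more compound is needed for the effect), compound 1 gives "not active" (no number reported).
Compound 2, `Cc1ncc(CO)c2c(Nc3ccccn3)c(N[C@@H](C)c3ccccc3)oc12`, in this assay compound 2 gives 4270 nM.
Compound 3, `CCCC(C)Nc1oc2c(C)ncc(CO)c2c1Nc1ccccn1`, in this assay compound 3 gives 9010 nM.

For the measured compounds named here, compound 3 stands highest of the two numbers available in this assay; the nearest is compound 2, and the one step between them, a 2.1-fold higher number from compound 2 to compound 3 (0.32 log units; beyond the scatter), is modest but beyond the scatter. Going by the values given here, compound 1, which carries nothing on that nitrogen, gives no number at all, so some substituent there appears needed for a measurable response; with only one such compound nothing more can be said.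

Compound 4, `Cc1ncc(CO)c2c(Nc3ccccn3)c(NC(C)(C)C)oc12`, is to be measured next. The change is tert-butyl in place of 1-methylbutyl on a nitrogen on an aromatic ring.

Among the compounds with values here, only the step from compound 2 to compound 3 bears on this: it swapped one branched group for another on the same nitrogen and moved the number modestly. The step to compound 4 again exchanges one branched alkyl for another, now shorter by the count shown, so a change of similar size or none beyond the scatter is expected; given that compound 1 without any group is not active, the expected direction is toward a higher number, a 1.4-fold higher number from compound 3 to compound 4 (0.16 log units; within the scatter). For compound 4 the estimated value in this assay is 13000 nM, with a range from 4500 nM to 40000 nM.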

Compound 4, half-maximal effective concentration: "not active" (no number reported)
Nothing numeric was reported for compound 4; there is nothing to compare the estimate with.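

In this assay, for the compounds shown here, compound 4 gives "not active" (no number reported) and so, like compound 1, offers no number, leaving no step from compound 3 to compound 4 to read. No measurement shown here accounts for this result. Open, as far as these compounds go, is what in the group on that nitrogen separates compound 2 and compound 3, which give numbers, from compound 1 and compound 4.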